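A few compounds are considered here, and "the series" means these few. Any claim that something is new, unique, unknown or untested is made for them only; others in the source may bear on it.

In an assay on HEK293 cells for inhibition of sodium-dependent dopamine transporter (Homo sapiens) (on this read-out lower numbers stand for stronger inhibition and higher numbers for weaker inhibition), compound 2 `COc1cc(Cl)ccc1Oc1ccncc1CN(C)C` gives 10200 nM.
In this assay compound 1 `CNCc1cnccc1Oc1ccc(Cl)cc1OC` gives "not determined" (no result reported).

Going by the values given here, compound 2 is the only compound here with a number; compound 1 has no reported result, so nothing can be said about it. Compound 3 `CN(C)Cc1cnccc1Oc1ccc(Cl)cc1Br` differs from compound 2 by bromo in place of methoxy on an aromatic carbon. Among the compounds with values here, no measured pair shows what such an exchange does, so the step is expected to stay within the usual scatter, leaning slightly toward stronger inhibition. Compound 3 is therefore estimated at 7000 nM in this assay, with a range from 2500 nM to 20000 nM, an expected step of a 1.5-fold lower number from compound 2 to compound 3 (0.16 log units; within the scatter).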

Compound 3, half-maximal inhibitory concentration: 1970 nM
The estimate for compound 3 lay 3.6-fold (0.55 log units) above the measured number, and the stated range ends above it.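

Putting bromo in place of methoxy on this aromatic carbon gives a 5.2-fold lower number from compound 2 to compound 3 (0.71 log units; beyond the scatter) in this assay and, with the step beyond the scatter, the read-out clearly responds to what sits at this position. The earlier compounds shown here could not show this, as they offered no measured pair. No available evidence explains why this exchange gives stronger inhibition. From the compounds shown here alone, whether fluoro, methyl or a nitrile on this carbon would lower the number as well remains open. So does whether any other group here could go further than bromo.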